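The source may hold more compounds than are shown below. What is called first, only, known or untested is meant among the compounds shown, and "the series" means these compounds.

Working notes on the cytotoxicity series. Two compounds share the core and are measured: compound 1 `CCC1(Cc2ccccc2)OS(=O)(=O)C=C1OCCCCc1ccccc1` and compound 2 `CCC1(Cc2ccccc2)OS(=O)(=O)C=C1OC`. In an ADME assay on HEL cells (Homo sapiens) for cytotoxicity, with a stated time of 3 days (a lower number here means that less compound is tolerated, a higher number that more compound is tolerated), compound 1 gives 99000 nM. For compound 2 the read-out in this assay is only a limit of the assay, > 200000 nM. Within the data shown here, the single measured step, an at least 2.0-fold higher number from compound 1 to compound 2 (0.30 log units; that floor lies within the scatter), is accordingly known only as a floor, resting on (the limit of > 200000 nM in this assay, at which 1 of the 2 values shown sits), and its true size may be larger.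

Compound 3 `CCC1(Cc2ccccc2)OS(=O)(=O)C=C1OCc1ccc(Cl)cc1` is not yet measured. It differs from compound 2 by 4-chlorophenyl in place of hydrogen on a saturated chain carbon bound to an oxygen on an unsaturated carbon. Among the measured compounds shown here, the change runs in the opposite sense to the one measured step: an aromatic group is put back onto the same saturated chain carbon from which a 3-phenylpropyl had been taken away. Because an at least 2.0-fold higher number from compound 1 to compound 2 (0.30 log units; that floor lies within the scatter) showed that removing such a group raised the number, restoring an aromatic group is expected to lower it, with a size on the order of that step or somewhat less, since the entering group is shorter than the one that left. Compound 3 is therefore estimated to reach 100000 nM in this assay, within 40000 nM to 200000 nM, which corresponds to an expected step of an at least 2.0-fold lower number from compound 2 to compound 3 (0.30 log units; that floor lies within the scatter). A reading that again ends at the limit cannot be excluded for compound 3.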

Compound 3, half-maximal cytotoxic concentration: > 200000 nM
Compound 3 gave a limit, no number; the forecaster's own chance of this, stated with the estimate: 30%; middle value at least 2.0-fold (0.30 log units) from the limit.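

In this assay compound 3 gives > 200000 nM, which is a limit of the assay and not a number; an aromatic ring on this saturated chain carbon bound to an oxygen on an unsaturated carbon is thus not enough on its own to bring the read-out into the measurable range. Exchanging 3-phenylpropyl for 4-chlorophenyl at this place gives an at least 2.0-fold higher number from compound 1 to compound 3 (0.30 log units; that floor lies within the scatter), a size known only as a floor, so compound 1 remains the only one of the series with a true number. The step that joins the two limits cannot be read, and the position can be compared only against compound 1, with the read-outs bunched as follows: the limit of > 200000 nM in this assay, at which 2 of the 3 values shown sit.

From the compounds shown here alone, whether the number of compound 1 depends on the length of the chain, on its end phenyl, or on both stays open, as does the part played by the chlorine in 4-chlorophenyl. Also open, going by these compounds, is how an amine, a carboxylic acid or a chain longer than 3-phenylpropyl would read at this place.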